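This account rests on a few compounds, and the source may have more. Where it says the series, first, only, none or still open, it means among the compounds named here.

Compound 2 `COc1ccc(-c2cccc(C(=O)Nc3nn[nH]n3)n2)cc1` gives 12% in a functional assay on the whole organism for inhibition, with Rattus norvegicus as the target, at a dose of 1 mg/kg by the oral route; on this read-out higher numbers stand for a stronger effect at the one dose given and lower numbers for a weaker effect. Going by the values given here, of the two numbers measured so far it stands lowest: compound 1 `COc1ccc(-c2cc(OC)cc(C(=O)Nc3nn[nH]n3)n2)cc1` gives 25% in this assay, and the single measured step, a number 13 percentage points lower from compound 1 to compound 2 (beyond the scatter), lies beyond the scatter. Compound 3 `CNc1ccc(-c2cccc(C(=O)Nc3nn[nH]n3)n2)cc1` differs from compound 2 by methylamino in place of methoxy on an aromatic carbon. Among the compounds with values here, the only measured step bearing on this carbon is the one between compound 1 and compound 2, which removed the methoxy entirely; no measured step exchanges the methoxy for methylamino, so the guidance is indirect. That step was modest in size, and the new group, like the one it replaces, carries a hydrogen-bond acceptor. For compound 3 the expected step is therefore a number 5 percentage points higher from compound 2 to compound 3 (within the scatter), small and not clearly beyond the scatter. The estimate for compound 3 is 17%, with a range from 4% to 34%.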

Compound 3, a percentage reported as inhibition, in the whole organism at one dose (the size of the read-out at that dose, not a potency): 71%
Compound 3: the middle estimate sits 54 percentage points below what was measured; the whole stated range lies below it.
By their numbers in this assay, from the lowest: compound 2; then compound 1; then compound 3.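

In this assay, exchanging methoxy for methylamino on this aromatic carbon, para to a large group, gives a number 59 percentage points higher from compound 2 to compound 3 (beyond the scatter). The earlier compounds shown here did not show that this carbon could respond so strongly to a change that keeps the heavy-atom count and the hydrogen-bond acceptor count the same, while swapping oxygen for nitrogen and adding a hydrogen-bond donor. Nothing available explains why this exchange has so large an effect.

The compounds shown leave open whether a plain amine or a dimethylamino group on this carbon would give a similar read-out, which would indicate whether the hydrogen on the nitrogen or the nitrogen itself goes with the higher number. They also leave open whether methylamino here would combine with the second methoxy of compound 1 to give a still higher number.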